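This account rests on a few compounds, and the source may have more. Where it says the series, first, only, none or still open, it means among the compounds named here.

In a functional assay on OVCAR-8 cells (Homo sapiens) for inhibition, read by sulforhodamine B assay, with a stated time of 48 h (a higher number here means a weaker inhibitor of growth, a lower number a stronger inhibitor of growth), compound 1 `O=C(Cc1csc2nc(-c3ccc(Br)cc3)cn12)N/N=C/c1ccccc1` gives 20400 nM and compound 2 `O=C(Cc1csc2nc(-c3ccc(Br)cc3)cn12)N/N=C/c1ccc(O)cc1` gives 25700 nM, so compound 2 stands level with compound 1 within the scatter. Compound 3 `O=C(Cc1csc2nc(-c3ccc(Br)cc3)cn12)N/N=C/c1ccc(Cl)cc1Cl` differs from compound 2 as follows: 2,4-dichlorophenyl in place of 4-hydroxyphenyl on a carbon with a double bond to nitrogen. Among the compounds with values here, the only measured step, a 1.3-fold higher number from compound 1 to compound 2 (0.10 log units; within the scatter), comes from hydroxy in place of hydrogen on an aromatic carbon. Within the data shown here, it speaks to the hydroxy group alone, and no measured compound here carries chlorine. Only a small change is therefore expected, an estimated 1.3-fold lower number from compound 2 to compound 3 (0.11 log units; within the scatter). For compound 3 the estimate is 20000 nM, with an expected range from 9000 nM to 45000 nM.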

Compound 3, concentration for total growth inhibition: 50100 nM
The estimate for compound 3 lay 2.5-fold (0.40 log units) below the measured number, outside the stated range (above it).
By their numbers in this assay, from the lowest: compounds 1, 2 and 3 (each within the scatter of the next, the first and the last beyond it).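

In this assay, within the data shown here, 2,4-dichlorophenyl in place of phenyl gives a 2.5-fold higher number from compound 1 to compound 3 (0.39 log units; beyond the scatter), the first step here beyond the scatter, so this position on the carbon with a double bond to nitrogen does respond to change, modestly and towards weaker growth inhibition. In place of 4-hydroxyphenyl, the same group gives a 1.9-fold higher number from compound 2 to compound 3 (0.29 log units; within the scatter), which stays within the scatter. Nothing available explains the step. Still open, as far as these compounds go, is whether a single chloro group would give a similar step, and whether an amine or a carboxylic acid on that phenyl ring would lower the number instead.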